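The compounds below may be only part of what the source reports. "The series", "measured", "known", "first", "only" and "open" are said of these compounds alone.

Measured compounds:

- compound 1, `CCCSc1nc(N/N=C/c2ccc(C)cc2)c2nnn(Cc3ccccc3)c2n1`, > 64000 nM in a functional assay on MCF7 cells (Homo sapiens) for antiproliferative activity, read by MTT assay, with a stated time of 72 h; a lower number here means a stronger inhibitor, a higher number a weaker inhibitor
- compound 2, `CCCSc1nc(N/N=C(\C)c2ccccc2O)c2nnn(Cc3ccccc3Cl)c2n1`, > 64000 nM in this assay
- compound 3, `CCCSc1nc(N/N=C/c2cc(OC)c(OC)c(OC)c2)c2nnn(Cc3ccccc3)c2n1`, > 64000 nM in this assay

Compound 1 gives only a limit of the assay, > 64000 nM, in this assay and no number. Compound 2 likewise stops at a limit, > 64000 nM. Compound 3 also returns a limit, > 64000 nM. Among the measured compounds shown here, nothing in this assay therefore places compound 1 relative to the others: all three values rest on (the limit of > 64000 nM in this assay, at which 3 of the 3 values shown sit), and no step between any two of them can be read off.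

Compound 4, `CCCSc1nc(N/N=C/c2ccc([N+](=O)[O-])cc2)c2nnn(Cc3ccccc3)c2n1`, is the next compound in the series and has not yet been measured in this assay. Against compound 1 it shows (nitro in place of methyl on an aromatic carbon), the change standing on the 4-methylphenyl ring, which becomes 4-nitrophenyl.

For the measured compounds named here, no measured step tells how far a change of this kind moves the value in this assay. With every value shown sitting at the limit of > 64000 nM in this assay, at which 3 of the 3 values shown sit, there is no basis to expect a step beyond the scatter, and the most likely outcome is again a limit. Compound 4 is therefore expected to fall at 100000 nM, within 20000 nM to 500000 nM, which means an expected step that the limit leaves unreadable from compound 1 to compound 4.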

Compound 4, half-maximal inhibitory concentration: 11000 nM
Estimate against measurement, compound 4: 9.1-fold (0.96 log units) above; measured number below the stated range.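

Among the compounds shown here, the aromatic carbon para to a large group is a position that can move the read-out: in this assay, nitro in place of methyl gives an at least 5.8-fold lower number from compound 1 to compound 4 (0.76 log units; beyond the scatter) and thus the first measured step. Compound 1 has only a limit, > 64000 nM, so this step is a minimum and its full size cannot be read. Compound 4 is also the only compound shown with a number rather than a limit, which makes the 4-nitrophenyl compound the sole point of measurable activity on the shared core: the limit of > 64000 nM in this assay, at which 3 of the 4 values shown sit.

On these data alone, with a single replacement at this position, it remains open whether the step is specific to nitro or would also appear with another group there, such as a nitrile, an amine or a carboxylic acid. As far as these compounds go, it is also open whether nitro would give a comparable step with a different chain on the sulfur, such as a longer chain in place of propyl, or on a core carrying another substituted benzyl group.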